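This account rests on a few compounds, and the source may have more. Where it says the series, first, only, none or still open, it means among the compounds named here.

Working notes on the series, read in a functional assay on HCT-116 cells (Homo sapiens) for antiproliferative activity, with a stated time of 48 h; on this read-out higher numbers stand for weaker inhibition and lower numbers for stronger inhibition. Compound 1 (`CCN(CC)c1ccc(-c2cccc(OC)c2)nn1`) gives > 25000 nM, which is a limit and not a number. Compound 2 (`CCN(CC)c1ccc(-c2cccc(Cl)c2)nn1`) gives > 25000 nM, again a limit. Compound 3 (`CCN(CC)c1ccc(-c2cccc(C#N)c2)nn1`) gives > 25000 nM, also a limit. Compound 3 therefore has no readable position, and all that is shown is the limit of > 25000 nM in this assay, at which 3 of the 3 values shown sit.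

Compound 4 (`CCCCOc1ccc(-c2cccc(C#N)c2)nn1`) carries this change: butoxy in place of diethylamino on an aromatic carbon. The measured steps are a step that the two limits leave unreadable from compound 1 to compound 2, then a step that the two limits leave unreadable from compound 1 to compound 3, and finally a step that the two limits leave unreadable from compound 2 to compound 3. All three change the other aromatic substituent and keep diethylamino, so none gives a size for this swap. Only a move towards stronger inhibition could be read from compound 3, and a further result at the limit remains quite likely.

The estimate implies an at least 1.6-fold lower number from compound 3 to compound 4 (0.22 log units; that floor lies within the scatter), which is expected to be modest and towards stronger inhibition. For compound 4 the estimated value is 15000 nM, with an expected range from 3000 nM to 50000 nM.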

Compound 4, half-maximal inhibitory concentration: > 25000 nM
Compound 4: no number, only a limit (the forecaster's own chance of this, stated with the estimate: 55%); middle value at least 1.6-fold (0.22 log units) away from the limit.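

Compound 4 gives > 25000 nM, again a limit and not a number, so the step from compound 3 to compound 4 cannot be read: the limit of > 25000 nM in this assay, at which 4 of the 4 values shown sit.

The compounds shown leave open how large the swap of butoxy for diethylamino is, and which change to the shared core would bring a measurable value.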